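From Phenyl to Pyridin-3-yl on a Shared Core

A few compounds are considered here, and "the series" means these few. Any claim that something is new, unique, unknown or untested is made for them only; others in the source may bear on it.

Compound 1 `Nc1nc(-c2ccc(C3CC3)o2)nc2sc(Cc3ccccc3)cc12` gives 861 nM in a functional assay on CHO-K1 cells for antagonist activity at adenosine receptor A1 (Homo sapiens), read by a beta-galactosidase reporter and cAMP accumulation, with stated times of 15 min and 6 h; a lower number here means a stronger inhibitor, a higher number a weaker inhibitor.
Compound 2 `Nc1nc(-c2ncco2)nc2sc(Cc3ccccc3)cc12` gives 310 nM in this assay.
Compound 3 `Nc1nc(-c2ccccc2)nc2sc(Cc3ccccc3)cc12` gives 151 nM in this assay.

Compound 3 has the lowest number of the three; its nearest neighbour is compound 2 and the furthest is compound 1. The measured steps are a 2.8-fold lower number from compound 1 to compound 2 (0.44 log units; beyond the scatter), a 5.7-fold lower number from compound 1 to compound 3 (0.76 log units; beyond the scatter) and a 2.1-fold lower number from compound 2 to compound 3 (0.31 log units; beyond the scatter). Each of them sets a five-membered ring against another five-membered ring or against phenyl, and phenyl gave the lowest number in every comparison.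

Compound 4 `Nc1nc(-c2cccnc2)nc2sc(Cc3ccccc3)cc12` differs from compound 3 in one place: pyridin-3-yl in place of phenyl on an aromatic carbon. Among the compounds with values here, no measured step swaps one six-membered ring for another, so the three steps bear on this change only loosely. They show that departing from phenyl has so far raised the number, but only modestly, and here the ring size stays the same while one ring atom becomes a nitrogen. Compound 4 is therefore expected to sit close to compound 3, with the step of a 1.5-fold higher number from compound 3 to compound 4 (0.18 log units; within the scatter) expected to lie within the usual scatter. Compound 4 is estimated at 230 nM, with a range from 80 nM to 650 nM.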

Compound 4, inhibition constant: 1420 nM
Compound 4: middle estimate off by 6.2-fold (0.79 log units), on the low side; the whole stated range lies below it.
By their numbers in this assay, from the lowest: compound 3; then compound 2; then compounds 1 and 4 (each within the scatter of the next).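

In this assay, within the data shown here, pyridin-3-yl in place of phenyl, on an aromatic carbon between two ring nitrogen atoms, gives the largest step seen at this position (a 9.4-fold higher number from compound 3 to compound 4 (0.97 log units; beyond the scatter)), although the ring stays six-membered and only one ring carbon becomes a nitrogen. Keeping a six-membered aromatic ring here is therefore not enough to keep the number low: 1,3-oxazol-2-yl also does better than pyridin-3-yl (a 4.6-fold higher number from compound 2 to compound 4 (0.66 log units; beyond the scatter)), while the step from 5-cyclopropylfuran-2-yl (a 1.6-fold higher number from compound 1 to compound 4 (0.22 log units; within the scatter)) lies within the scatter. Nothing available here accounts for the size of the phenyl to pyridin-3-yl step.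

On these data alone, it remains open whether pyridin-2-yl or pyridin-4-yl would give a number closer to that of compound 3 or that of compound 4. Also open, as far as these compounds go, is how a phenyl carrying a methoxy group or a chlorine would compare with the unsubstituted phenyl of compound 3.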